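A Chloroquinazoline Swap Repeated on a Second Scaffold

The compounds below may be only part of what the source reports. "The series", "measured", "known", "first", "only" and "open" are said of these compounds alone.

Compound 1, `Cc1cccc(COc2ccc(/C=C/C(/C=C/c3ccccn3)=N/Oc3ncnc4cccc(C)c34)cc2)c1`, was tested in a functional assay on SMMC-7721 cells (Homo sapiens) for inhibition, read by MTT assay, with a stated time of 72 h, tested at 10 uM (a lower number here means a weaker effect, a higher number a stronger effect of the compound at the concentration tested), where compound 1 gives 97%. Compound 2, `Cc1cccc(COc2ccc(/C=C/C(/C=C/c3ccccn3)=N/Oc3ncnc4cc(Cl)ccc34)cc2)c1`, carries the change 7-chloroquinazolin-4-yl in place of 5-methylquinazolin-4-yl on an oxygen and in this assay compound 2 gives 95.6%, so the measured step is a number 1.4 percentage points lower from compound 1 to compound 2 (within the scatter). Compound 3, `Cc1cccc2ncnc(O/N=C(\C=C\c3ccccn3)/C=C/c3ccccc3OCc3ccc(Cl)cc3)c12`, belongs to a different core; how the core of compound 3 differs from the core of compound 1 is not broken down here. In this assay compound 3 gives 94.5%, which sits within the scatter of both compound 1 and compound 2. Compound 4, `Clc1ccc(COc2ccccc2/C=C/C(/C=C/c2ccccn2)=N/Oc2ncnc3cc(Cl)ccc23)cc1`, has not yet been measured; it differs from compound 3 by 7-chloroquinazolin-4-yl in place of 5-methylquinazolin-4-yl on an oxygen, the same change that turned compound 1 into compound 2, made at the same kind of place. Because the step of a number 1.4 percentage points lower from compound 1 to compound 2 (within the scatter) was within the scatter, the step from compound 3 to compound 4 is expected to be equally small, about a number 1 percentage points lower from compound 3 to compound 4 (within the scatter). Compound 4 is therefore estimated at 93.5% in this assay, most likely between 85% and 99%.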

Compound 4, a percentage reported as inhibition, at one concentration (the size of the read-out at that concentration, not a potency): 94.8%
Estimate against measurement, compound 4: 1.3 percentage points below; the range from low to high includes it.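

Measured in this assay, putting 7-chloroquinazolin-4-yl in place of 5-methylquinazolin-4-yl on the oxygen gives a number 0.3 percentage points higher from compound 3 to compound 4 (within the scatter). Set beside the earlier step on the other core, the change carries over with no difference that can be told apart from scatter: the same change on two cores in this assay, a number 1.4 percentage points lower (within the scatter) from compound 1 to compound 2 and a number 0.3 percentage points higher (within the scatter) from compound 3 to compound 4, 1.7 percentage points apart, within the scatter of two such steps This shows only that the swap left the read-out unmoved on both of these cores at the one concentration tested; it does not show how the two groups compare in potency, and two cores are too few to say how the change would behave on any further core in the series.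

The compounds shown carry only a methyl or a chlorine on the quinazolin-4-yl group, which leaves open how an amine or a carboxylic acid there would read in this assay. They also leave open whether the two groups would still read alike at lower concentrations, where one might give a stronger or weaker effect than the other.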